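The source may hold more compounds than are shown below. What is called first, only, known or untested is meant among the compounds shown, and "the series" means these compounds.

In an ADME assay on Caco-2 cells (Homo sapiens) for permeability, tested at 50 uM (a lower number here means that the compound crosses the layer more slowly, a higher number that the compound crosses the layer faster), three compounds sharing one core have been measured. Compound 1 (`COc1cc(C)c(S(=O)(=O)N(C)CCOCC(=O)N2CCN(CCN(C)C)CC2)c(C)c1`) gives 2.1 10^-6 cm/s and compound 3 (`COc1cc(C)c(S(=O)(=O)N(C)CCOCC(=O)N(C)Cc2ccc(C3=NCCN3)cc2)c(C)c1`) gives 1.3 10^-6 cm/s, two values within the scatter of each other. Compound 2 (`COc1cc(C)c(S(=O)(=O)N(C)CCOCC(=O)N2CCC(C(C)(C)CN(C)C)CC2)c(C)c1`) gives 13.6 10^-6 cm/s and lies beyond the scatter above compound 1, which therefore stands with compound 3 at the low end of this small set. Compound 4 (`CCN1CCC(N2CCN(C(=O)COCCN(C)S(=O)(=O)c3c(C)cc(OC)cc3C)CC2)CC1`) carries 1-ethylpiperidin-4-yl in place of 2-(dimethylamino)ethyl on an amine nitrogen in a ring. Among the measured compounds shown here, no measured pair shows this change, so only a small rise in this assay is expected, within the scatter (a 1.4-fold higher number from compound 1 to compound 4 (0.15 log units; within the scatter)). Compound 4 is estimated at 3 10^-6 cm/s (expected range 1.1 10^-6 cm/s to 8.5 10^-6 cm/s).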

Compound 4, apparent permeability: 1.7 10^-6 cm/s
For compound 4 the middle estimate is 1.8-fold (0.25 log units) above the measured one; low and high end bracket the measured number.
By their numbers in this assay, from the lowest: compounds 3, 4 and 1 (each within the scatter of the next); then compound 2.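

On the amine nitrogen in the ring, 1-ethylpiperidin-4-yl in place of 2-(dimethylamino)ethyl gives, in this assay, a 1.2-fold lower number from compound 1 to compound 4 (0.09 log units; within the scatter). Among the compounds shown here, this is the first step that can be read at this position, and it shows that the side group can gain a ring without the two numbers separating beyond the scatter. Nothing available explains this result. On these data alone, it remains open whether any group on this nitrogen can shift the number beyond the scatter. A carboxylic acid or a longer chain ending in an amine would test this.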